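Swapping the ether substituent on a translocator protein ligand

The source may report more compounds than this note shows. Statements on the series, on what has been measured and on what is new or still open speak of the compounds shown alone.

Compound 2 `CCN(CC)C(=O)CN(Cc1ccc(OCCF)cc1)c1cc(C)cc(C)c1` gives 1290 nM in an assay on membranes from HEK293 cells for displacement of a labelled ligand from Translocator protein (Homo sapiens), read by scintillation counting, with a stated time of 90 min; on this read-out lower numbers stand for stronger inhibition and higher numbers for weaker inhibition. Of the two measured compounds it has the higher number, yet the gap to compound 1 `CC(=O)N(Cc1ccc(OC(C)C)cc1)c1cc(C)cc(C)c1` is within the usual scatter, and in this assay compound 1 gives 823 nM, so neither stands apart from the other. Compound 3 `CCN(CC)C(=O)CN(Cc1ccc(OC(C)C)cc1)c1cc(C)cc(C)c1` differs from compound 2 by one change: isopropyl in place of 2-fluoroethyl on an oxygen on an aromatic ring. Going by the values given here, no measured pair shows this change alone, so no step beyond the scatter is expected in either direction. The estimated step of a 1.4-fold lower number from compound 2 to compound 3 (0.13 log units; within the scatter) is therefore small. Compound 3 is expected to give about 950 nM, with a range from 400 nM to 2500 nM.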

Compound 3, inhibition constant: 2240 nM
Compound 3: the middle estimate sits 2.4-fold (0.37 log units) below what was measured, within the range that was stated.
By their numbers in this assay, from the lowest: compounds 1, 2 and 3 (each within the scatter of the next, the first and the last beyond it).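

In this assay, isopropyl in place of 2-fluoroethyl on the oxygen gives a step that stays within the scatter (a 1.7-fold higher number from compound 2 to compound 3 (0.24 log units; within the scatter)), so this swap shows no clear effect at this position. Going by these compounds alone, on the nitrogen, (diethylcarbamoyl)methyl in place of acetyl gives the only step here beyond the scatter, and it is modest (a 2.7-fold higher number from compound 1 to compound 3 (0.43 log units; beyond the scatter)). Nothing available explains either step. Still open, from the compounds shown here alone, is whether an amine or a longer chain on that oxygen would shift the number. Also open, going by these compounds, is whether the nitrogen step would recur with 2-fluoroethyl on the oxygen.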